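The source may hold more compounds than are shown below. What is called first, only, known or untested is meant among the compounds shown, and "the series" means these compounds.

In a functional assay on HCT-116 cells (Homo sapiens) for antiproliferative activity, read by MTT assay, with a stated time of 24 h (on this read-out higher numbers stand for weaker inhibition and lower numbers for stronger inhibition), compound 3 `COc1cc(OC)c(-c2coc3cc(OCc4ccccc4C#N)ccc3c2=O)cc1OC` gives > 10000 nM, which is a limit and not a number. Compound 1 `COc1cc(OC)c(-c2coc3cc(OCC(=O)c4cccc(C(F)(F)F)c4)ccc3c2=O)cc1OC` also gives only a limit, > 10000 nM. Compound 2 `COc1cc(OC)c(-c2coc3cc(OCc4ccc(Br)cc4)ccc3c2=O)cc1OC` gives a true number, 1980 nM. Compound 4 `COc1cc(OC)c(-c2coc3cc(OCc4cccc(Br)c4)ccc3c2=O)cc1OC` differs from compound 3 as follows: 3-bromophenyl in place of 2-cyanophenyl on a saturated chain carbon bound to an oxygen on an aromatic ring. The closest measured change is an at least 5.0-fold higher number from compound 2 to compound 3 (0.70 log units; beyond the scatter), beyond the scatter, with 2-cyanophenyl in place of 4-bromophenyl. Also beyond the scatter is an at least 5.0-fold lower number from compound 1 to compound 2 (0.70 log units; beyond the scatter), whereas a step that the two limits leave unreadable from compound 1 to compound 3 cannot be sized. Since compound 4 also carries a bromophenyl, a modest move to a lower number is expected, of similar size to the first of these steps taken in reverse. The expected change is an at least 3.3-fold lower number from compound 3 to compound 4 (0.52 log units; beyond the scatter). For compound 4 the estimate is 3000 nM, with an expected range of 1000 nM to 10000 nM.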

Compound 4, half-maximal inhibitory concentration: 1200 nM
Compound 4: middle estimate off by 2.5-fold (0.40 log units), on the high side, and the stated range covers the measured number.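

A bromophenyl group at the meta-free wording of this place, on a saturated chain carbon bound to an oxygen on an aromatic ring, now gives a true number a second time, and 3-bromophenyl in place of 2-cyanophenyl yields an at least 8.3-fold lower number from compound 3 to compound 4 (0.92 log units; beyond the scatter). Moving to 3-bromophenyl from 4-bromophenyl gives a 1.7-fold lower number from compound 2 to compound 4 (0.22 log units; within the scatter), so the two bromophenyl compounds cannot be told apart, while the change from the (3-(trifluoromethyl)phenyl)carbonyl group gives an at least 8.3-fold lower number from compound 1 to compound 4 (0.92 log units; beyond the scatter). The steps from the two limits give only minimum sizes because they start from a limit: the limit of > 10000 nM in this assay, at which 2 of the 4 values shown sit.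

Going by these compounds, whether a chlorophenyl group, or a phenyl ring carrying an amine or a carboxylic acid, would read like the bromophenyl compounds stays open.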